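This account rests on a few compounds, and the source may have more. Where it says the series, first, only, none or still open, it means among the compounds named here.

Measured compounds:
- compound 1 `Clc1ccc(NCCNc2ccnc3cc(Cl)ccc23)c(Cl)c1`: in a toxicity assay on Huh-7 cells (Homo sapiens) for cytotoxicity, read by MTT assay, with a stated time of 72 h (on this read-out lower numbers stand for higher toxicity in this test and higher numbers for lower toxicity in this test), compound 1 gives > 100 ug/mL, a limit of the assay rather than a number.
- compound 2 `Fc1ccc(NCCNc2ccnc3cc(Cl)ccc23)cc1`: in this assay compound 2 gives > 100 ug/mL, again a limit and not a number.

Compound 1 and compound 2 share one core and differ only in the aryl group carried on the amine nitrogen. Neither gives a number in this assay; compound 2 stands at the ceiling of what was measured, and compound 1 sits there with it (the limit of > 100 ug/mL in this assay, at which 2 of the 2 values shown sit). Within the data shown here, no step between two measured compounds is therefore available, and nothing can be said about how much either aryl group matters for this read-out.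

Compound 3 `Clc1ccc2c(NCCNc3ccccc3Cl)ccnc2c1` is not yet measured. It differs from compound 2 by 2-chlorophenyl in place of 4-fluorophenyl on an amine nitrogen. Since both measured analogues sit at the same limit, the step of a number no higher from compound 2 to compound 3 (the limit leaves the size open) is expected to be none beyond the scatter. Compound 3 is accordingly expected to give about 100 ug/mL in this assay, within a range of 40 ug/mL to 150 ug/mL, and most probably the assay will again report only a limit.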

Compound 3, half-maximal cytotoxic concentration: > 100 ug/mL
Compound 3 ended at the assay's limit; the forecaster's own chance of this, stated with the estimate: 80%; the middle value sits exactly at the limit.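

Compound 3 joins compound 1 and compound 2 at the same limit, so no step from either of them to compound 3 can be read: the limit of > 100 ug/mL in this assay, at which 3 of the 3 values shown sit.

The compounds shown leave open how much the aryl group on the amine nitrogen matters in this assay, and what number each compound would give there.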